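The source may hold more compounds than are shown below. What is called first, only, known or untested is meant among the compounds shown, and "the series" means these compounds.

Compound 1 `O=c1n(Cc2cc3cc(Cl)ccc3n2CCCC(F)(F)F)c2cnccc2n1C1CC1` in an ADME assay on HeLa cells (Homo sapiens) for cytotoxicity, read by ATP content, with a stated time of 3 days; a higher number here means that more compound is tolerated, a lower number that less compound is tolerated: a limit, > 50000 nM
Compound 2 `O=c1n(Cc2nc3cnccc3n2CCCCO)c2cnccc2n1C1CC1`: a limit, > 100000 nM
Compound 3 `CS(=O)(=O)CCCn1c(Cn2c(=O)n(C3CNC3)c3ccncc32)cc2cc(Cl)ccc21`: a limit, > 50000 nM

None of the three measured compounds gives a number in this assay; each is known only as a limit. Compound 1 stands at the limit of > 50000 nM in this assay, at which 2 of the 3 values shown sit. Compound 2 stands at the limit of > 100000 nM in this assay, at which 1 of the 3 values shown sits. Going by the values given here, with all three values limits, no measured step can be sized, and nothing in the data separates the three compounds from one another.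

Compound 4 `N=C(CCCn1c(Cn2c(=O)n(C3CC3)c3ccncc32)cc2cc(Cl)ccc21)NO` differs from compound 1 in one place: a group of 4 heavy atoms (1 carbon, 2 nitrogen, 1 oxygen; no ring) in place of a group of 4 heavy atoms (1 carbon, 3 fluorine; no ring), on a saturated chain carbon, three bonds along the chain from an aromatic nitrogen. The trifluoromethyl leaves and a group with three hydrogen-bond donors and two hydrogen-bond acceptors enters on the saturated chain carbon. Since every measured compound sits at a limit in this assay, the expected step is none beyond the scatter, and the expectation is that compound 4 is likewise tolerated up to the limit. The step from compound 1 to compound 4 is estimated as a step that the limit leaves unreadable from compound 1 to compound 4. Compound 4 is expected at 60000 nM, between 25000 nM and 150000 nM.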

Compound 4, half-maximal cytotoxic concentration: > 50000 nM
Compound 4: no number, only a limit (the forecaster's own chance of this, stated with the estimate: 80%); the middle value lies beyond the limit too.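

In this assay compound 4 gives > 50000 nM, a limit and not a number, and the step from compound 1, itself known only as a limit, cannot be read. The compounds shown leave open where any of them would reach half-maximal cytotoxicity, and whether replacing trifluoromethyl changes it.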